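The source may report more compounds than this note shows. Statements on the series, on what has been measured and on what is new or still open speak of the compounds shown alone.

Measured compounds:
- compound 1, `COc1nc2ccc(Br)cc2cc1C(c1ccccc1)n1cc(-c2ccc(Br)cc2)nn1`: 13.4%
- compound 2, `CCCCCCCCc1cn(C(c2ccccc2)c2cc3cc(Br)ccc3nc2OC)nn1`: 2.06%

In an ADME assay on SK-OV-3 cells (Homo sapiens) for cytotoxicity, read by sulforhodamine B assay, with a stated time of 48 h, tested at 10 uM (on this read-out higher numbers stand for more inhibition at the one concentration tested (going by the name of the read-out) and lower numbers for less inhibition), compound 2 stands lowest of the two numbers; the nearest is compound 1, separated by a number 11.3 percentage points lower from compound 1 to compound 2 (beyond the scatter), a step beyond the scatter. Compound 3, `COc1nc2ccc(Br)cc2cc1C(c1ccccc1)n1cc(CO)nn1`, is not yet measured. It differs from compound 2 by hydroxy in place of heptyl on a saturated chain carbon bound to an aromatic carbon. For the measured compounds named here, the only measured step, a number 11.3 percentage points lower from compound 1 to compound 2 (beyond the scatter), exchanges one group on an aromatic carbon for another and does not touch the chain carbon altered here, so there is no measured step that bears on the change from compound 2 to compound 3. With nothing to go on but the two values shown, the expected step of a number 5.9 percentage points higher from compound 2 to compound 3 (within the scatter) is taken as none beyond the scatter in this assay. Compound 3 is therefore estimated at 8% in this assay, with a range from -5% to 25%.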

Compound 3, a percentage reported as inhibition, at one concentration (the size of the read-out at that concentration, not a potency): 3.23%
The estimate for compound 3 lay 4.8 percentage points above the measured number, within the range that was stated.
By their numbers in this assay, from the lowest: compounds 2 and 3 (each within the scatter of the next); then compound 1.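

In this assay, replacing heptyl with hydroxy on a saturated chain carbon bound to an aromatic carbon gives a number 1.2 percentage points higher from compound 2 to compound 3 (within the scatter), so octyl and hydroxymethyl read alike at this place despite their difference in size. For the compounds shown here, the low reading of compound 2 is thus not particular to octyl, as the second non-aromatic group gives a number 10.2 percentage points lower from compound 1 to compound 3 (beyond the scatter) and leaves 4-bromophenyl as the only group here set apart beyond the scatter. Nothing on hand accounts for this difference.

As far as these compounds go, whether the higher number of compound 1 depends on the ring or on its bromine remains open, and a plain phenyl or a 4-chlorophenyl on the same aromatic carbon would separate the two. Also open is how an aminomethyl or a carboxylic acid would read there, since the two non-aromatic groups shown span only a long chain and a hydroxymethyl.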